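This account rests on a few compounds, and the source may have more. Where it says the series, first, only, none or still open, it means among the compounds named here.

In a functional assay on L02 cells (Homo sapiens) for inhibition, read by Griess assay, with stated times of 1 h and 24 h (on this read-out higher numbers stand for weaker inhibition and lower numbers for stronger inhibition), compound 1, with the structure `Brc1ccc(CNc2nc(/C=C/c3ccccc3)nc3ccsc23)cc1`, gives only a limit of the assay, > 1000000 nM. That reading is described as the limit of > 1000000 nM in this assay, at which 1 of the 2 values shown sits. Compound 2, with the structure `COc1cc(/C=C/c2nc(N3CCCC3)c3sccc3n2)cc(OC)c1OC`, gives in this assay a half-maximal inhibitory concentration of 681000 nM. Among the two values shown compound 2 stands as the only one reported as a number, the other being a limit, so no measured step between two numbered compounds exists here from which a trend could be drawn.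

Compound 3, with the structure `COc1cc(/C=C/c2nc(OCc3ccccc3)c3sccc3n2)cc(OC)c1OC`, has not yet been measured. It differs from compound 2 by benzyloxy in place of pyrrolidin-1-yl on an aromatic carbon. No comparable change is present among the measured pairs, so the direction of the step can be read from nothing shown.

With only the weak inhibition of compound 2 to rest on, compound 3 is expected to land near the same level, with a step from compound 2 of a 1.3-fold higher number from compound 2 to compound 3 (0.12 log units; within the scatter) in this assay, which does not go beyond the usual scatter. The estimate for compound 3 is therefore 900000 nM, with a range from 300000 nM to 3000000 nM, and a real chance that this assay returns only a limit.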

Compound 3, half-maximal inhibitory concentration: > 1000000 nM
Compound 3 ended at the assay's limit (the forecaster's own chance of this, stated with the estimate: 45%); middle value at least 1.1-fold (0.04 log units) away from the limit.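

This is the first change shown at this aromatic carbon, next to the ring nitrogen, and it gives an at least 1.4-fold higher number from compound 2 to compound 3 (0.16 log units; that floor lies within the scatter) in this assay on going to benzyloxy in place of pyrrolidin-1-yl. The exchange therefore brings no measurable gain in inhibition: an oxygen-linked benzyl group at this place does not rescue the weak reading of compound 2, and the printed floor fixes neither the true size of the step nor whether it exceeds the scatter. The reading for this position now has one number and one limit, and the series as a whole rests largely on limits: the limit of > 1000000 nM in this assay, at which 2 of the 3 values shown sit.

The compounds shown leave open whether any group at this carbon can give a clearly stronger reading than compound 2, for instance a smaller cyclic amine such as azetidin-1-yl, a morpholin-4-yl ring, a simple methoxy or a primary amine. They also leave open whether the pyrrolidin-1-yl of compound 2 matters at all, and a carboxylic acid or a longer alkylamine chain at the same place would bear on that question.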